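A few compounds are considered here, and "the series" means these few. Any claim that something is new, unique, unknown or untested is made for them only; others in the source may bear on it.

Measured so far in an ADME assay on microsomes from liver (Homo sapiens) for metabolic stability, with a stated time of 30 min, tested at 1 uM; on this read-out higher numbers stand for a longer-lived compound and lower numbers for a shorter-lived compound:

- compound 1, `COc1cccc(CN2C(=O)CN(C(=O)c3cc4cc(OC)ccc4o3)C[C@@H]2CCc2ccccc2)c1`: 0.128 h
- compound 2, `COc1cccc(CN2C(=O)CN(C(=O)c3cc4cc(OC)ccc4[nH]3)C[C@@H]2c2ccccc2)c1`: 0.118 h
- compound 3, `COc1ccc2[nH]c(C(=O)N3CC(=O)N(Cc4ccccc4)[C@@H](N4CCc5ccccc54)C3)cc2c1`: 0.25 h

All three compounds share the core and are short-lived in this assay. Compound 3 gives the highest of the three numbers; its gap to compound 1 lies within the usual scatter, its gap to compound 2 beyond it. No pair of these compounds differs in a single place, so no single-point step is available.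

Compound 4, `COc1ccc2[nH]c(C(=O)N3CC(=O)N(Cc4ccccc4)[C@@H](CN4CCCc5ccccc54)C3)cc2c1`, has yet to be measured in this assay. It differs from compound 3 in one place: (1,2,3,4-tetrahydroquinolin-1-yl)methyl in place of 2,3-dihydro-1H-indol-1-yl on a saturated ring carbon. Among the compounds with values here, nothing among the measured compounds isolates this change, so no direction can be taken from a measured step. With all three numbers so close together, no step beyond the scatter is expected here, and the estimated step from compound 3 to compound 4 is a 1.3-fold lower number from compound 3 to compound 4 (0.10 log units; within the scatter). Compound 4 is therefore expected to give about 0.2 h in this assay, within a range from 0.08 h to 0.5 h.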

Compound 4, half-life: 0.183 h
Compound 4: the middle estimate sits 1.1-fold (0.04 log units) above what was measured; measured number inside the range.
By their numbers in this assay, from the lowest: compounds 2, 1, 4 and 3 (each within the scatter of the next, the first and the last beyond it).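

In this assay, within the data shown here, the exchange at this saturated ring carbon gives a 1.4-fold lower number from compound 3 to compound 4 (0.14 log units; within the scatter), the first single-place step. The larger (1,2,3,4-tetrahydroquinolin-1-yl)methyl group, with a six-membered in place of a five-membered non-aromatic ring, is thus accepted here without a shift beyond the scatter, and the half-life stays short. Nothing available gives a reason for this result.

The step joins two changes, the ring size and the added methylene link, and the compounds shown do not separate them: neither a (2,3-dihydro-1H-indol-1-yl)methyl group nor 1,2,3,4-tetrahydroquinolin-1-yl stands among them. Also open, going by these compounds, is whether a morpholin-4-ylmethyl group or a carboxylic acid on this carbon would move the half-life beyond the scatter.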